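This account rests on a few compounds, and the source may have more. Where it says the series, first, only, none or still open, it means among the compounds named here.

Measured so far in a functional assay (B cells) with Mus musculus as the target; on this read-out higher numbers stand for an effect only at larger amounts of compound and lower numbers for an effect already at smaller amounts:
- compound 1 `NCC(O)Cn1c(=O)n(C2OC(CO)[C@@H](O)[C@H]2O)c2nc(N)nc(O)c21`: 28 uM
- compound 2 `C=CCn1c(=S)n(C2OC(COCc3ccccc3)[C@H]3OC(C)(C)O[C@@H]23)c2nc(N)nc(O)c21`: 47 uM

Compound 1 holds the lower of the two numbers in this assay, but the gap to compound 2 is within the scatter, so no order between the two can be read from these data.

Compound 3 `Cn1c(=O)n(C2OC(CO)[C@@H](O)[C@H]2O)c2nc(N)nc(O)c21` is not yet measured in this assay. It differs from compound 1 by hydrogen in place of 2-amino-1-hydroxyethyl on a saturated chain carbon bound to an aromatic nitrogen. Among the measured compounds shown here, no measured pair shows the effect of such a change, so nothing anchors its direction. The remaining substituent on the aromatic nitrogen shrinks to a methyl, and a small shift toward higher numbers, or none beyond the scatter, is expected; the step is estimated as a 1.4-fold higher number from compound 1 to compound 3 (0.15 log units; within the scatter).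

Compound 3 is thus expected near 40 uM, with a range from 12 uM to 140 uM.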

Compound 3, concentration for half-maximal effect: 10 uM
Compound 3: the middle estimate sits 4.0-fold (0.60 log units) above what was measured, outside the stated range (below it).
By their numbers in this assay, from the lowest: compound 3; then compounds 1 and 2 (each within the scatter of the next).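

In this assay, the change from 3-amino-2-hydroxypropyl to methyl gives a 2.8-fold lower number from compound 1 to compound 3 (0.45 log units; beyond the scatter). Among the compounds shown here, this is the first step that can be read at this place, and it shows that the 2-amino-1-hydroxyethyl on the saturated chain carbon bound to an aromatic nitrogen is not required for activity at this level: the compound carrying only hydrogen there holds the lower number. No measurement available here bears on what lies behind this step.

A single pair cannot separate the contributions of the amine, the hydroxyl and the chain length. A plain propyl, a 3-hydroxypropyl or a 3-aminopropyl in this place would be needed to assign the step, and an ethyl would show whether the trend with chain length is gradual.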